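This account rests on a few compounds, and the source may have more. Where it says the series, first, only, none or still open, it means among the compounds named here.

Of the compounds shown here, three sharing one core have been measured in a functional assay on CHO-K1 cells with Glucose-dependent insulinotropic receptor (Homo sapiens) as the target, read by a luciferase reporter, with a stated time of 5 h; on this read-out lower numbers stand for smaller maximal responses and higher numbers for larger maximal responses. Compound 1 `CC(C)OC(=O)N1CCC(Oc2ncnc3c2CCN3c2ccc(S(C)(=O)=O)cn2)CC1` gives 111%, compound 2 `CC(C)OC(=O)N1CCC(Oc2ncnc3c2CCN3c2ccc(C#N)c(F)c2)CC1` gives 121%, and compound 3 `CC(C)OC(=O)N1CCC(Oc2ncnc3c2CCN3c2ccc([S+]([O-])N(C)C)cc2)CC1` gives 128%. Compound 3 thus stands at the top of the three numbers, but only its gap to compound 1 lies beyond the scatter: a number 17 percentage points higher from compound 1 to compound 3 (beyond the scatter), whereas a number 7 percentage points higher from compound 2 to compound 3 (within the scatter). Compound 4 `CC(C)OC(=O)N1CCC(Oc2ncnc3c2CCN3c2ccc([S@+](C)[O-])c(F)c2)CC1` has not yet been measured in this assay. It differs from compound 3 in one place: a group of 10 heavy atoms (7 carbon, 1 oxygen, 1 fluorine, 1 sulfur; one six-membered aromatic ring of carbon only) in place of a group of 11 heavy atoms (8 carbon, 1 nitrogen, 1 oxygen, 1 sulfur; one six-membered aromatic ring of carbon only), on a nitrogen on an aromatic ring in a ring. Going by the values given here, two measured steps bear on this change, since both alter the same group on the same nitrogen. The step from compound 1 to compound 3 was modest and beyond the scatter, while the step from compound 2 to compound 3 stayed within it. The group entering carries a fluorine, as compound 2 does, and a sulfur, as compounds 1 and 3 both do. A small lowering, or none beyond the scatter, is therefore expected: a number 10 percentage points lower from compound 3 to compound 4 (within the scatter). Compound 4 is estimated at 118%, with a range from 100% to 135%.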

Compound 4, largest response reached (reported as percent of maximum), in percent of the reference or control that the assay uses: 122%
The estimate for compound 4 lay 4 percentage points below the measured number, within the range that was stated.
By their numbers in this assay, from the lowest: compounds 1, 2, 4 and 3 (each within the scatter of the next, the first and the last beyond it).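

In this assay, the group on the nitrogen of the five-membered ring tolerates a further swap: a number 6 percentage points lower from compound 3 to compound 4 (within the scatter). The sharpest comparison is a change on a single aromatic carbon, where a group of carbon, oxygen and sulfur replaces the nitrile: a number 1 percentage points higher from compound 2 to compound 4 (within the scatter). Against the 5-(methylsulfonyl)pyridin-2-yl group, the new group gives a modest step beyond the scatter, a number 11 percentage points higher from compound 1 to compound 4 (beyond the scatter), but no measurement here explains any of these numbers.

The compounds shown leave open whether the defined stereocentre at sulfur matters, since only one arrangement appears, and whether the fluorine matters, since no pair differs by that atom alone. They also leave open how an amine or a carboxylic acid on that aromatic ring would read in this assay.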